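The source may hold more compounds than are shown below. What is called first, only, known or untested is meant among the compounds shown, and "the series" means these compounds.

Values measured in a functional assay on R2 cells (Cricetulus griseus) for inhibition, with R2 (Homo sapiens) as the target, read by CellTiter-Blue, with a stated time of 96 h; a lower number here means a stronger inhibitor, a higher number a weaker inhibitor:
- Compound 1 `Nc1nc2[nH]c(CCCCCC(=O)N[C@@H](CCC(=O)O)C(=O)O)cc2c(=O)[nH]1`: > 1000 nM
- Compound 2 `Nc1nc2[nH]c(CCCCCCCCC(=O)N[C@@H](CCC(=O)O)C(=O)O)cc2c(=O)[nH]1`: > 1000 nM
- Compound 3 `Nc1nc2[nH]c(CCCCCC(=O)O)cc2c(=O)[nH]1`: > 1000 nM

Each of these values is a limit of the assay and not a number. Compound 3 stands at > 1000 nM, which is a limit. Among the compounds with values here, it shares that position with the other two compounds, as the limit of > 1000 nM in this assay, at which 3 of the 3 values shown sit, records, so the series offers no numerical value and no measured step to work from.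

Compound 4 `Nc1nc2[nH]c(CCCCCCCC(=O)O)cc2c(=O)[nH]1` departs from compound 3 in one place: 2-carboxyethyl in place of carboxy on a saturated chain carbon, five bonds along the chain from an aromatic carbon. In words, 2-carboxyethyl stands in place of carboxy on a saturated chain carbon, five bonds along the chain from an aromatic carbon.

In this assay, no step beyond the scatter is expected, and no direction can be given. Within the data shown here, every compound so far sits at the same limit, including compound 3 at > 1000 nM. Compound 4 is therefore most likely to be reported as a limit too. The expected change is a step that the limit leaves unreadable from compound 3 to compound 4. For compound 4 the estimated value is 3000 nM, with an expected range from 1000 nM to 10000 nM.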

Compound 4, half-maximal inhibitory concentration: > 1000 nM
Compound 4 was reported as a limit; the forecaster's own chance of this, stated with the estimate: 90%; the middle value is on the limit's open side.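

In this assay compound 4, like compound 3, is reported only as a limit, so no step can be read between these two compounds. The compounds shown leave open how strongly any of them inhibits and whether 2-carboxyethyl in place of carboxy changes that, as all share one limit: the limit of > 1000 nM in this assay, at which 4 of the 4 values shown sit.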